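Removing a nitro group from a sulfonyl amide series

The source may hold more compounds than are shown below. What is called first, only, known or untested is meant among the compounds shown, and "the series" means these compounds.

Measured so far:
compound 1 `CCC(C)C(C(=O)Nc1ccc(C(C)=O)cc1)N(C(=O)c1ccccc1)S(=O)(=O)c1ccc([N+](=O)[O-])cc1`, 50000000 nM
compound 2 `CC(=O)c1ccc(NC(=O)C2CC(O)CN2S(=O)(=O)c2ccc([N+](=O)[O-])cc2)cc1`, 7100000 nM
compound 3 `CCC(C)C(C(=O)Nc1ccc(C(C)=O)cc1)N(C(=O)c1ccccc1)S(=O)(=O)c1ccccc1`, 8600000 nM

All three were tested in a functional assay, read by spectrophotometry, with a stated time of 20 min; a lower number here means a stronger inhibitor, a higher number a weaker inhibitor. Compound 1 and compound 3 share one core, while compound 2 has a different core; the difference between the two cores is not broken down here. Compound 3 differs from compound 1 by hydrogen in place of nitro on an aromatic carbon, and this gave a 5.8-fold lower number from compound 1 to compound 3 (0.76 log units; beyond the scatter). Compound 4 `CC(=O)c1ccc(NC(=O)C2CC(O)CN2S(=O)(=O)c2ccccc2)cc1` is not yet measured; it differs from compound 2 by hydrogen in place of nitro on an aromatic carbon, the same change at the same place. The step from compound 2 to compound 4 is therefore expected to be of similar size, a 4.7-fold lower number from compound 2 to compound 4 (0.68 log units; beyond the scatter), because the earlier change gave a 5.8-fold lower number from compound 1 to compound 3 (0.76 log units; beyond the scatter). Compound 4 is estimated at 1500000 nM, with a range from 500000 nM to 5000000 nM.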

Compound 4, half-maximal inhibitory concentration: 3800000 nM
Compound 4: the middle estimate sits 2.5-fold (0.40 log units) below what was measured; the measured number falls inside the stated range.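

In this assay, swapping the nitro group for hydrogen on the core of compound 2 gave a 1.9-fold lower number from compound 2 to compound 4 (0.27 log units; within the scatter) and so produced no clear change. Among the compounds shown here, with only two pairs, this cannot show which difference between the two cores matters, or how the change would behave on any other core. It does show that a step seen on one core cannot simply be assumed to carry over to the other, since its size was not kept: the same change on two cores in this assay, a 5.8-fold lower number (0.76 log units; beyond the scatter) from compound 1 to compound 3 and a 1.9-fold lower number (0.27 log units; within the scatter) from compound 2 to compound 4, 3.1-fold (0.49 log units) apart, beyond the scatter of two such steps.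

From the compounds shown here alone, whether a third core would follow compound 1 and compound 3 or compound 2 and compound 4 remains open. So does how an amine, a carboxylic acid or a methoxy group would compare with nitro and hydrogen on the same aromatic carbon.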